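A few compounds are considered here, and "the series" means these few. Any claim that something is new, unique, unknown or untested is made for them only; others in the source may bear on it.

Three measured compounds share one core and differ only in the ring attached to the sulfonyl sulfur. In an assay on isolated protein for displacement of a labelled ligand from metabotropic glutamate receptor 5 (Homo sapiens), with a stated time of 60 min, tested at 1 uM (a higher number here means more inhibition at the concentration tested (going by the name of the read-out), a lower number less inhibition), compound 1 `CC1CCN(c2c(S(=O)(=O)c3ccc(F)cc3)cnc3ccc(Cl)cc23)CC1` gives 89%, compound 2 `CC1CCN(c2c(S(=O)(=O)c3ccccc3)cnc3ccc(Cl)cc23)CC1` gives 59%, and compound 3 `CC1CCN(c2c(S(=O)(=O)c3ccc(Cl)c(Cl)c3)cnc3ccc(Cl)cc23)CC1` gives 86%. Compound 3 thus sits second highest of the three: its gap to compound 1 is within the scatter, while the step of a number 27 percentage points higher from compound 2 to compound 3 (beyond the scatter) is beyond it. The unmeasured compound 4 `COc1cccc(S(=O)(=O)c2cnc3ccc(Cl)cc3c2N2CCC(C)CC2)c1` arises from compound 3 by the change (3-methoxyphenyl in place of 3,4-dichlorophenyl on a sulfonyl sulfur). Within the data shown here, two measured steps bear on this: a number 27 percentage points higher from compound 2 to compound 3 (beyond the scatter) shows that 3,4-dichlorophenyl in place of phenyl raised inhibition, and a number 30 percentage points lower from compound 1 to compound 2 (beyond the scatter) shows that hydrogen in place of fluoro lowered it, whereas a number 3 percentage points lower from compound 1 to compound 3 (within the scatter) shows the two halogen-bearing rings behaving alike. Going by these compounds, no methoxy-bearing ring has been tested here, so its effect is unknown; a modest drop is expected rather than none, since compound 2 gave 59% with a bare phenyl while the substituted rings of compound 1 and compound 3 gave more. The expected step is therefore a number 16 percentage points lower from compound 3 to compound 4 (beyond the scatter). Compound 4 is expected to give about 70%, within a likely range from 45% to 90%.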

Compound 4, a percentage reported as inhibition, at one concentration (the size of the read-out at that concentration, not a potency): 87%
Estimate against measurement, compound 4: 17 percentage points below; the range from low to high includes it.
By their numbers in this assay, from the lowest: compound 2; then compounds 3, 4 and 1 (each within the scatter of the next).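

In this assay, the 3-methoxyphenyl ring on the sulfonyl sulfur cannot be told apart from the two halogen-bearing rings, with a number 1 percentage points higher from compound 3 to compound 4 (within the scatter) and a number 2 percentage points lower from compound 1 to compound 4 (within the scatter). Among these compounds, then, a halogen on the ring is not needed for the higher readings: methoxy in place of hydrogen also gives a clear rise, a number 28 percentage points higher from compound 2 to compound 4 (beyond the scatter). Nothing measured here explains why such different rings read alike.

Going by these compounds, it remains open whether the number in this assay stays level with a ring bearing an amine or a carboxylic acid, or with a saturated ring such as cyclohexyl in place of the aromatic one. Each number is also a reading at a single concentration, so compounds that read alike here may still differ at other concentrations.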